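Swapping iodo for nitro on a potent thiosemicarbazone

The source may hold more compounds than are shown below. What is called first, only, known or untested is meant among the compounds shown, and "the series" means these compounds.

Compound 1 `CC(=NNC(=S)Nc1ccc(I)cc1)c1ccccn1` gives 6.6 nM in a functional assay on MCF7 cells (Homo sapiens) for cytotoxicity, read by MTT assay, with a stated time of 48 h (a higher number here means a weaker inhibitor, a lower number a stronger inhibitor), the lowest of the three numbers, though compound 2 `C/C(=N/NC(=S)Nc1ccc(I)cc1)c1ccccn1` at 6.61 nM and compound 3 `C/C(=N\NC(=S)Nc1ccc(I)cc1)c1ccccn1` at 6.61 nM sit within the scatter of it. Those three differ only in how the double bond is drawn, as the fact that one of compounds 1 and 2 is drawn with a defined configuration and the other without, at the place where they differ, the fact that one of compounds 1 and 3 is drawn with a defined configuration and the other without, at the place where they differ and the fact that compounds 2 and 3 differ only in the configuration as drawn show, so the steps of a 1.0-fold higher number from compound 1 to compound 2 (0.00 log units; within the scatter), a 1.0-fold higher number from compound 1 to compound 3 (0.00 log units; within the scatter) and no change at the digits printed from compound 2 to compound 3 (within the scatter) are all flat. Compound 4 `CC(=NNC(=S)Nc1ccc([N+](=O)[O-])cc1)c1ccccn1` makes a real change: nitro in place of iodo on an aromatic carbon. Within the data shown here, no measured step probes that swap, so the expectation rests on nothing but the starting point. Compound 4 is estimated at 15 nM (range 3 nM to 80 nM), a step of a 2.3-fold higher number from compound 1 to compound 4 (0.36 log units; beyond the scatter) that is expected but uncertain.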

Compound 4, half-maximal inhibitory concentration: 52 nM
Compound 4: middle estimate off by 3.5-fold (0.54 log units), on the low side; the range from low to high includes it.
By their numbers in this assay, from the lowest: compounds 1, 2 and 3 (each within the scatter of the next); then compound 4.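

Where redrawing the double bond changed nothing, nitro in place of iodo gives a 7.9-fold higher number from compound 1 to compound 4 (0.90 log units; beyond the scatter) in this assay on this aromatic carbon. The group at this position therefore matters to the result, and this swap takes the number clearly upward. Nothing available here accounts for the size of this step. Going by these compounds, with only iodo and nitro at this position, it remains open whether other groups, such as an amine, a methoxy group or plain hydrogen, would stay near compound 1 or move towards compound 4.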